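Anilide series: phenoxy to methoxy on the anilide ring

The compounds below may be only part of what the source reports. "The series", "measured", "known", "first", "only" and "open" are said of these compounds alone.

Measured so far:
compound 1 `O=C(CCCCCCn1cc(-c2cccnc2)nn1)Nc1ccccc1-c1ccccc1`, 88.2%
compound 2 `O=C(CCCCCCn1cc(-c2cccnc2)nn1)Nc1ccccc1Oc1ccccc1`, 81.3%

In a functional assay on SH-SY5Y cells (Homo sapiens) for cytotoxicity, tested at 300 nM (a lower number here means a stronger effect, a higher number a weaker effect of the compound at the concentration tested), compound 2 gives 81.3%, which lies within the scatter of compound 1. Going by the values given here, the one measured step, a number 6.9 percentage points lower from compound 1 to compound 2 (within the scatter), changed the substituent on the anilide ring without effect beyond the scatter. Compound 3 `COc1ccccc1NC(=O)CCCCCCn1cc(-c2cccnc2)nn1` differs from compound 2 by methyl in place of phenyl on an oxygen on an aromatic ring. Among the compounds with values here, no measured step covers this exact change, so the single step at this position is the only guide. For compound 3 a step of a number 1.7 percentage points higher from compound 2 to compound 3 (within the scatter) is expected, none beyond the scatter. Compound 3 is estimated at 83%, within 70% to 96%.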

Compound 3, a percentage reported as activity, at one concentration (the size of the read-out at that concentration, not a potency): 87.9%
For compound 3 the middle estimate is 4.9 percentage points below the measured one; the measured number falls inside the stated range.
By their numbers in this assay, from the lowest: compounds 2, 3 and 1 (each within the scatter of the next).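

In this assay, methyl in place of phenyl on the oxygen gives a number 6.6 percentage points higher from compound 2 to compound 3 (within the scatter), and methoxy in place of phenyl on the aromatic carbon gives a number 0.3 percentage points lower from compound 1 to compound 3 (within the scatter). Phenyl, phenoxy and methoxy therefore cannot be told apart at this position, and losing the six-membered aromatic ring from the oxygen moves the read-out by no more than the scatter. No measurement bearing on this result is available. Still open, from the compounds shown here alone, is whether an amine or a carboxylic acid at this place, or a longer chain in the shared core, would shift the number beyond the scatter.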